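This account rests on a few compounds, and the source may have more. Where it says the series, first, only, none or still open, it means among the compounds named here.

Working notes on the series.

For the measured compounds named here, compound 3 `COc1ccc(F)cc1CNCCCNc1ccnc2cc(-c3cccc4ccccc34)ccc12` stands at the top of the three numbers so far in an ADME assay for permeability, using PAMPA, with a stated time of 30 min, at pH 7.4 (a lower number here means that the compound crosses the layer more slowly, a higher number that the compound crosses the layer faster), where compound 3 gives 237 10^-6 cm/s. Compound 1 `COc1ccc(F)cc1CNCCCNc1ccnc2cc(Cc3cc(C)cc(C)c3)ccc12` gives 23 10^-6 cm/s and compound 2 `COc1ccc(F)cc1CNCCCNc1ccnc2cc(CCC(C)C)ccc12` gives 23 10^-6 cm/s; the step of no change at the digits printed from compound 1 to compound 2 (within the scatter) shows that swapping one saturated-chain substituent for another left the number where it was. Both routes to compound 3 were large: a 10-fold higher number from compound 1 to compound 3 (1.01 log units; beyond the scatter) and a 10-fold higher number from compound 2 to compound 3 (1.01 log units; beyond the scatter).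

The next compound is compound 4 `COc1ccc(F)cc1CNCCCNc1ccnc2cc(Cc3cccc(C(F)(F)F)c3)ccc12`. The change from compound 3 is 3-(trifluoromethyl)benzyl in place of naphthalen-1-yl on an aromatic carbon. This reverses the kind of move that produced the large gain in compound 3, returning to a benzyl-type substituent on the same aromatic carbon as in compound 1. The two steps that bear on it are a 10-fold higher number from compound 1 to compound 3 (1.01 log units; beyond the scatter) and a 10-fold higher number from compound 2 to compound 3 (1.01 log units; beyond the scatter), both of the same size and direction; the expectation is therefore a step back down of comparable size, a 7.9-fold lower number from compound 3 to compound 4 (0.90 log units; beyond the scatter). Compound 4 is thus estimated at 30 10^-6 cm/s in this assay, within a range from 12 10^-6 cm/s to 90 10^-6 cm/s.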

Compound 4, apparent permeability: 23 10^-6 cm/s
For compound 4 the middle estimate is 1.3-fold (0.12 log units) above the measured one; low and high end bracket the measured number.
By their numbers in this assay, from the lowest: compounds 1, 2 and 4 (each within the scatter of the next); then compound 3.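

In this assay, the 3-(trifluoromethyl)benzyl group on this aromatic carbon reads with the 3,5-dimethylbenzyl and isopentyl groups (no change at the digits printed from compound 1 to compound 4 (within the scatter); no change at the digits printed from compound 2 to compound 4 (within the scatter)), so the three cannot be told apart here. Compound 3, with naphthalen-1-yl bound directly to the aromatic carbon, stands alone among the four compounds (a 10-fold lower number from compound 3 to compound 4 (1.01 log units; beyond the scatter)), and the step back shows that a benzyl group carrying a trifluoromethyl substituent does not keep its high number. No measurement at hand accounts for this split.

From the compounds shown here alone, it remains open whether the high number of compound 3 goes with an aromatic ring bound directly to this carbon or with the two fused rings of naphthalen-1-yl. Going by these compounds, how a plain phenyl group on this carbon, or an amine on the benzyl ring, would read in this assay also remains open.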